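The compounds below may be only part of what the source reports. "The series", "measured", "known", "first", "only" and "open" are said of these compounds alone.

Measured so far:
compound 1 `CN1CCN(CCCCCn2c3c(c4ccccc42)C(=O)c2c[n+]([O-])c4ccccc4c2C3=O)CC1`: 830 nM
compound 2 `O=C1c2c[n+]([O-])c3ccccc3c2C(=O)c2[nH]c3ccccc3c21`: 1380 nM
compound 3 `CC1(C)OC[C@@H](Cn2cc(Cn3c4c(c5ccccc53)C(=O)c3c[n+]([O-])c5ccccc5c3C4=O)nn2)O1`: > 1000 nM (a limit of the assay, not a number)

In a functional assay on SH-SY5Y cells (Homo sapiens) for cytotoxicity, read by MTT assay, with a stated time of 72 h (on this read-out higher numbers stand for weaker inhibition and lower numbers for stronger inhibition), compound 1 gives 830 nM, the lowest of the two numbers reported. Compound 2 stands nearest, a 1.7-fold higher number from compound 1 to compound 2 (0.22 log units; within the scatter). For compound 3 the result is only a limit, (the limit of > 1000 nM in this assay, at which 1 of the 3 values shown sits).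

Compound 4 `O=C1c2c[n+]([O-])c3ccccc3c2C(=O)c2c1c1ccccc1n2Cc1cn(C[C@H](O)CO)nn1` differs from compound 1 by 1-(2,3-dihydroxypropyl)-1H-1,2,3-triazol-4-yl in place of 4-(4-methylpiperazin-1-yl)butyl on a saturated chain carbon bound to an aromatic nitrogen. Within the data shown here, the one measured step at this place, hydrogen in place of 5-(4-methylpiperazin-1-yl)pentyl, ran a 1.7-fold higher number from compound 1 to compound 2 (0.22 log units; within the scatter). Compound 3 also carries a 1H-1,2,3-triazol-4-yl ring on this saturated chain carbon and reached only the limit. A step to a higher number, near the edge of the scatter, is expected a 1.8-fold higher number from compound 1 to compound 4 (0.26 log units; within the scatter). Compound 4 is estimated at 1500 nM, in the range 700 nM to 3500 nM.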

Compound 4, half-maximal inhibitory concentration: > 1000 nM
Compound 4 was reported as a limit; the forecaster's own chance of this, stated with the estimate: 45%; the middle value does not contradict the limit.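

On the saturated chain carbon bound to an aromatic nitrogen, 1-(2,3-dihydroxypropyl)-1H-1,2,3-triazol-4-yl in place of 4-(4-methylpiperazin-1-yl)butyl gives an at least 1.2-fold higher number from compound 1 to compound 4 (0.08 log units; that floor lies within the scatter). Compound 4, with 1,2-dihydroxyethyl, is a limit and not a number, as is compound 3, with 2,2-dimethyl-1,3-dioxolan-4-yl: the limit of > 1000 nM in this assay, at which 2 of the 4 values shown sit. The steps to compound 4 from compound 2 and from compound 3 cannot be read.

Going by these compounds, how far the triazole compounds lie from compound 1 stays open. Also open, on these data alone, is whether a triazole carrying a primary amine or a carboxylic acid in place of 2,3-dihydroxypropyl would give a number in this assay.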